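Replacing a dibromohydroxyphenyl hydrazone with a difluorophenyl

The source may hold more compounds than are shown below. What is called first, only, known or untested is meant among the compounds shown, and "the series" means these compounds.

Measured compounds, all in a functional assay on MKN-45 cells (Homo sapiens) for cytotoxicity, read by MTT assay, with a stated time of 72 h; on this read-out lower numbers stand for stronger inhibition and higher numbers for weaker inhibition:
compound 1, `CN(C)CCn1cnnc1-c1cc(Oc2ccc(NC(=O)N/N=C/c3cc(C(C)(C)C)cc(C(C)(C)C)c3O)cc2F)ccn1`, compound 1 gives 3300 nM
compound 2, `CN(C)CCn1cnnc1-c1cc(Oc2ccc(NC(=O)N/N=C/c3cc(Br)c(O)c(Br)c3)cc2F)ccn1`, compound 2 gives 4320 nM
compound 3, `Cn1ncnc1-c1cc(Oc2ccc(NC(=O)N/N=C/c3ccccc3)cc2F)ccn1`, compound 3 gives > 100000 nM, which is a limit of the assay and not a number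

Three compounds share an aryl hydrazone carbonyl urea attached through an ether to a pyridyl triazole core. Compound 2 and compound 1 lie within the usual scatter of each other in this assay, so no order between them can be read; the third value, that of compound 3, is a limit (the limit of > 100000 nM in this assay, at which 1 of the 3 values shown sits). Compound 3 carries a plain phenyl on the carbon with a double bond to nitrogen and also a methyl rather than a dimethylaminoethyl on its triazole, so its limit cannot be tied to one change alone.

The unmeasured compound 4, `CN(C)CCn1cnnc1-c1cc(Oc2ccc(NC(=O)N/N=C/c3ccc(F)cc3F)cc2F)ccn1`, keeps the dimethylaminoethyl triazole of compound 2 and alters only the aryl hydrazone: 2,4-difluorophenyl in place of 3,5-dibromo-4-hydroxyphenyl on a carbon with a double bond to nitrogen. Compound 4 therefore loses the hydroxyl and both bromines that compound 2 carries, moving toward the phenyl pattern of compound 3.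

Compound 4 is expected to be weaker, with an estimated step of a 4.6-fold higher number from compound 2 to compound 4 (0.67 log units; beyond the scatter) in this assay. Compound 4 is estimated at 20000 nM, within a range from 5000 nM to 100000 nM.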

Compound 4, half-maximal inhibitory concentration: 810 nM
Estimate against measurement, compound 4: 25-fold (1.39 log units) above; the whole stated range lies above it.
By their numbers in this assay, from the lowest: compound 4; then compounds 1 and 2 (each within the scatter of the next). At a limit, above all of these: compound 3.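

In this assay, the aryl hydrazone proves open to change while the rest of compound 2 stays fixed, with a 5.3-fold lower number from compound 2 to compound 4 (0.73 log units; beyond the scatter). Going by these compounds alone, the hydroxyl and both bromines of the 3,5-dibromo-4-hydroxyphenyl can therefore all leave together without a loss in this read-out, and the 2,4-difluorophenyl that enters, with no hydrogen-bond donor or acceptor by the count for this change, gives the lower number; the earlier compounds offered no single step at this place, since compound 1 and compound 2 were not linked by one and compound 3 differs in more than one place. Nothing shown here gives a cause for this step.

The change removes the hydroxyl and both bromines and adds both fluorines in one move, and the compounds shown do not separate the contribution of any one of these. Going by these compounds, whether a monofluorophenyl, a methoxyphenyl or an aminophenyl on the same carbon with a double bond to nitrogen would follow compound 4 or compound 2 remains open.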